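From carboxy to isopentyloxycarbonyl on compound 2

The source may hold more compounds than are shown below. What is called first, only, known or untested is meant among the compounds shown, and "the series" means these compounds.

- Compound 1 (`C=C(C)CCOC(=O)C[C@@H]1C(C(=O)OC)=CO[C@@H](O[C@@H]2O[C@H](COC(C)=O)[C@@H](OC(C)=O)[C@H](OC(C)=O)[C@H]2OC(C)=O)/C1=C/C`) gives (> 15000 nM), a limit
- Compound 2 (`C/C=C1/[C@H](O[C@@H]2O[C@H](COC(C)=O)[C@@H](OC(C)=O)[C@H](OC(C)=O)[C@H]2OC(C)=O)OC=C(C(=O)OC)[C@H]1CC(=O)O`) gives (> 15000 nM), a limit

In a functional assay on SK-BR-3 cells (Homo sapiens) for antiproliferative activity, read by MTT assay, with a stated time of 72 h (a higher number here means a weaker inhibitor, a lower number a stronger inhibitor), compound 2 stands at (> 15000 nM), which is a limit and not a number. Among the measured compounds shown here, the same holds across the series so far (the limit of > 15000 nM in this assay, at which 2 of the 2 values shown sit). Compound 3 (`C/C=C1/[C@H](O[C@@H]2O[C@H](COC(C)=O)[C@@H](OC(C)=O)[C@H](OC(C)=O)[C@H]2OC(C)=O)OC=C(C(=O)OC)[C@H]1CC(=O)OCCC(C)C`) carries isopentyl in place of hydrogen on an oxygen next to a carbonyl group. For the measured compounds named here, the one measured step that bears on this change is a step that the two limits leave unreadable from compound 1 to compound 2, so it offers no size to carry over. No clear step in either direction is therefore expected, and this assay may again report only a limit. The expected change is a step that the limit leaves unreadable from compound 2 to compound 3. For compound 3 the estimate is 18000 nM, with an expected range from 6000 nM to 40000 nM.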

Compound 3, half-maximal inhibitory concentration: > 15000 nM
Compound 3: a limit, no number; the forecaster's own chance of this, stated with the estimate: 80%; the middle value is on the limit's open side.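

In this assay, among the compounds shown here, compound 1, compound 2 and compound 3 all give a limit and not a number, so no step between them can be read. Going by these compounds, whether hydrogen, isopentyl or 3-methylbut-3-en-1-yl on that oxygen changes activity at all stays open.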